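The source may report more compounds than this note shows. Statements on the series, on what has been measured and on what is new or still open speak of the compounds shown alone.

In a functional assay on the whole organism (strain Sprague-Dawley) for inhibition, with Rattus norvegicus as the target, with a stated time of 10 min (a lower number here means that less compound is needed, a higher number that more compound is needed for the effect), compound 1 `Cn1c(-c2ccccc2)ncc(C(=O)O)c1=O` gives 50 mg/kg. Compound 2 `CCOc1ccccc1-c1ncc(C(=O)O)c(=O)n1C` gives only a limit, > 50 mg/kg. Compound 3 `COc1nc(-c2ccccc2)ncc1C(=O)O` likewise gives only a limit, > 10 mg/kg.

Compound 1 and compound 2 differ in one place: ethoxy in place of hydrogen on an aromatic carbon. The step of a number no lower from compound 1 to compound 2 (the limit leaves the size open) cannot be sized, since compound 2 sits at the limit of > 50 mg/kg in this assay, at which 1 of the 3 values shown sits. Compound 3 sits at the limit of > 10 mg/kg in this assay, at which 1 of the 3 values shown sits; how its core differs from the core of compound 1 is not broken down here. Compound 4 `CCOc1ccccc1-c1ncc(C(=O)O)c(OC)n1`, not yet measured, differs from compound 3 by the same change: ethoxy in place of hydrogen on an aromatic carbon. Because the measured step of a number no lower from compound 1 to compound 2 (the limit leaves the size open) moved no lower, compound 4 is expected to give a limit as well, with an estimated value of 50 mg/kg. The step expected from compound 3 to compound 4 is a step that the limit leaves unreadable from compound 3 to compound 4.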

Compound 4, dose for 50% inhibition: > 5 mg/kg
Compound 4 was reported as a limit; the forecaster's own chance of this, stated with the estimate: 85%; the middle value lies beyond the limit too.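

For the compounds shown here, compound 3 and compound 4 are both reported only as limits, so no step between them can be read. The compounds shown leave open how large a step ethoxy in place of hydrogen gives on either core.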